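Swapping bromine for fluorine on the anilide ring

The source may report more compounds than this note shows. Statements on the series, on what has been measured and on what is new or still open speak of the compounds shown alone.

Of the compounds shown here, three sharing one core have been tested in a functional assay on SMMC-7721 cells (Homo sapiens) for cytotoxicity, read by MTT assay, with a stated time of 72 h; on this read-out lower numbers stand for stronger inhibition and higher numbers for weaker inhibition. Compound 1, `O=C(CSC(=S)N[C@H]1CCOC1=O)Nc1ccc(Br)cc1`, is the only one to give a definite number: in this assay compound 1 gives 28300 nM. Compound 2, `O=C(CSC(=S)N[C@H]1CCOC1=O)Nc1ccc(Cl)cc1Cl`, reaches only the limit of the assay, > 128000 nM. Compound 3, `O=C(CSC(=S)N[C@H]1CCOC1=O)Nc1cccc(C(F)(F)F)c1`, likewise stops at the limit, > 128000 nM. So compound 1 stands alone with a measured value, while the other two sit at the limit of > 128000 nM in this assay, at which 2 of the 3 values shown sit, which means no number was obtained for them.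

Compound 4, `O=C(CSC(=S)N[C@H]1CCOC1=O)Nc1ccc(F)cc1`, has not yet been measured. It differs from compound 1 in a single change: fluoro in place of bromo on an aromatic carbon. The two halogen analogues that did return only a limit are not direct single-change partners of compound 1, so the size of this particular step cannot be read from any measured pair. The expectation is therefore uncertain, leaning towards a weakening beyond the scatter or a result at the limit. The step of a 2.1-fold higher number from compound 1 to compound 4 (0.33 log units; beyond the scatter) is the expected size of that change. Compound 4 is expected to give about 60000 nM, with a plausible range from 15000 nM to 200000 nM, in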

Compound 4, half-maximal inhibitory concentration: > 128000 nM
Compound 4: no number, only a limit; the forecaster's own chance of this, stated with the estimate: 40%; middle value at least 2.1-fold (0.32 log units) away from the limit.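

Within the data shown here, this is the first direct single-change pair, and it shows that the group at this position matters: going from 4-bromophenyl to 4-fluorophenyl gives an at least 4.5-fold higher number from compound 1 to compound 4 (0.65 log units; beyond the scatter) in this assay. The change is small on paper, with one heavy atom leaving, one entering, and no ring, hydrogen-bond donor, hydrogen-bond acceptor or net charge involved, yet that single exchange is enough to lose a definite reading. Compound 4 returns only a limit, so the step has a floor but no known full size, and compound 1 remains the only compound in the set with a measured number: the limit of > 128000 nM in this assay, at which 3 of the 4 values shown sit.

Going by these compounds, whether an iodo group, a methyl group or an amine on the same aromatic carbon would keep a definite reading, or improve on compound 1, stays open. With one pair and a single cell line, it is also unknown whether the same exchange of bromo for fluoro would have a similar effect on a different core or in other cells.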